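The compounds below may be only part of what the source reports. "The series", "measured", "known", "first", "only" and "open" are said of these compounds alone.

Measured so far:
Compound 1 `Nc1nc(NCc2cccnc2)nc2sc(-c3ccco3)nc12` — in an assay on CHO cells for displacement of a labelled ligand from adenosine receptor A3 (Homo sapiens), read by scintillation counting, with a stated time of 120 min (on this read-out higher numbers stand for weaker inhibition and lower numbers for stronger inhibition), compound 1 gives 18.2 nM.
Compound 2 `Nc1nc(NCc2cnccn2)nc2sc(-c3ccco3)nc12` — in this assay compound 2 gives 157 nM.

Compound 2 stands at the higher of the two numbers, separated from compound 1 by an 8.6-fold higher number from compound 1 to compound 2 (0.94 log units; beyond the scatter). Compound 3 `Nc1nc(NCc2ccsc2)nc2sc(-c3ccco3)nc12` differs from compound 2 by thiophen-3-yl in place of pyrazin-2-yl on a saturated chain carbon bound to a nitrogen on an aromatic ring. Among the measured compounds shown here, no measured step exchanges a six-membered ring for a five-membered one; the only step at hand, an 8.6-fold higher number from compound 1 to compound 2 (0.94 log units; beyond the scatter), shows that exchanging one aromatic ring for another at this place can move the number well beyond the scatter. Compound 3 is therefore expected to give a lower number than compound 2, with an estimate of 45 nM and a range of 12 nM to 170 nM, corresponding to an expected step of a 3.5-fold lower number from compound 2 to compound 3 (0.54 log units; beyond the scatter).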

Compound 3, inhibition constant: 3.14 nM
Compound 3: middle estimate off by 14-fold (1.16 log units), on the high side, and the stated range ends above it.
By their numbers in this assay, from the lowest: compound 3; then compound 1; then compound 2.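

In this assay, among the compounds shown here, the place on a saturated chain carbon bound to a nitrogen on an aromatic ring proves more sensitive than the one earlier step showed: thiophen-3-yl in place of pyrazin-2-yl gives a 50-fold lower number from compound 2 to compound 3 (1.70 log units; beyond the scatter) and thiophen-3-yl in place of pyridin-3-yl gives a 5.8-fold lower number from compound 1 to compound 3 (0.76 log units; beyond the scatter) in turn. A five-membered aromatic ring with 1 hetero atom thus gives a lower number here than either six-membered ring shown.

As far as these compounds go, whether thiophen-2-yl, plain phenyl or a longer chain ending in an amine would hold this number stays open. No evidence at hand accounts for the order of the three compounds.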